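This account rests on a few compounds, and the source may have more. Where it says the series, first, only, none or still open, it means among the compounds named here.

Compound 1, `C=C1C[C@]23C[C@@]1(O)CC[C@@H]2c1cccc(C)c1[C@@H]3Cn1cc(-c2ccc(OC)cc2)nn1`, in a functional assay on A549 cells (Homo sapiens) for cytotoxicity, read by MTT assay, with a stated time of 4 days (on this read-out lower numbers stand for stronger inhibition and higher numbers for weaker inhibition), gives > 20000 nM, which is a limit of the assay rather than a number.
Compound 2, `C=C1C[C@]23C[C@@]1(O)CC[C@@H]2c1cccc(C)c1[C@@H]3Cn1cc(-c2ccccn2)nn1`, in this assay gives > 20000 nM, again a limit of the assay.
Compound 3, `C=C1C[C@]23C[C@@]1(O)CC[C@@H]2c1cccc(C)c1[C@@H]3Cn1cc(-c2ccccc2)nn1`, in this assay gives > 20000 nM, also a limit of the assay.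

Compound 3 therefore stands nowhere in particular among the numbers: all three measured compounds sit at the same limit, as summarized by the limit of > 20000 nM in this assay, at which 3 of the 3 values shown sit. Going by these compounds, the three steps between them, a step that the two limits leave unreadable from compound 1 to compound 2, a step that the two limits leave unreadable from compound 1 to compound 3 and a step that the two limits leave unreadable from compound 2 to compound 3, cannot be read, because each compound reaches only a limit; whether exchanging the aryl group on the triazole shifts potency at all is unknown.

Compound 4, `C=C1C[C@]23C[C@@]1(O)CC[C@@H]2c1cccc(C)c1[C@@H]3Cn1cc(-c2ccc(F)cc2)nn1`, differs from compound 3 by fluoro in place of hydrogen on an aromatic carbon. Going by the values given here, no measured step bears directly on this change. Among the compounds with values here, the only evidence is that the three aryl variants measured so far, including the 4-methoxyphenyl of compound 1 and the pyridin-2-yl of compound 2, all remain at the limit in this assay. On that basis compound 4 is expected to stay at the limit as well, with a step that the limit leaves unreadable from compound 3 to compound 4 expected to be a step that cannot be read. The estimate for compound 4 in this assay is 35000 nM, with a range from 15000 nM to 150000 nM.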

Compound 4, half-maximal inhibitory concentration: > 20000 nM
Compound 4 ended at the assay's limit; the forecaster's own chance of this, stated with the estimate: 85%; the middle value lies beyond the limit too.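

In this assay compound 4 gives > 20000 nM, a limit of the assay and not a number. Going by these compounds alone, no step from compound 1, compound 2 or compound 3 to compound 4 can be read, as all four sit at one limit: the limit of > 20000 nM in this assay, at which 4 of the 4 values shown sit. The compounds shown leave open whether exchanging the aryl group on the triazole changes potency at all.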